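Lengthening the nitrile chain on the tetrabromo core

The source may hold more compounds than are shown below. What is called first, only, known or untested is meant among the compounds shown, and "the series" means these compounds.

Measured so far in a functional assay on MCF7 cells (Homo sapiens) for cytotoxicity, read by MTT assay, with a stated time of 24 h, tested at 10 uM; a lower number here means a stronger effect, a higher number a weaker effect of the compound at the concentration tested:
compound 1, `Cc1nc2c(Br)c(Br)c(Br)c(Br)c2n1CCCC#N`, gives 65%
compound 2, `Cc1nc2c(Br)c(Br)c(Br)c(Br)c2n1CCC#N`, gives 85%
compound 3, `N#CCCn1cnc2c(Br)c(Br)c(Br)c(Br)c21`, gives 81%

Compound 3 stands second highest of the three numbers in this assay. Its nearest neighbour is compound 2, whose value of 85% lies within the scatter of it; the gap to compound 1 lies beyond the scatter, as a number 4 percentage points lower from compound 2 to compound 3 (within the scatter) and a number 20 percentage points higher from compound 1 to compound 2 (beyond the scatter) together show.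

Compound 4, `N#CCCCn1cnc2c(Br)c(Br)c(Br)c(Br)c21`, is not yet measured. The change from compound 3 to compound 4 is cyanomethyl in place of cyano on a saturated chain carbon, two bonds along the chain from an aromatic nitrogen. Going by the values given here, one measured step bears on it directly and runs the same change in reverse: a number 20 percentage points higher from compound 1 to compound 2 (beyond the scatter). The step of a number 4 percentage points lower from compound 2 to compound 3 (within the scatter) shows that the methyl on the shared core makes no difference beyond the scatter, so the reverse of the first step is expected to carry over to the unmethylated core. The expected step is therefore a number 18 percentage points lower from compound 3 to compound 4 (beyond the scatter), a lower number and a stronger effect. Compound 4 is estimated at 63%, with a range from 50% to 78%.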

Compound 4, a percentage reported as activity, at one concentration (the size of the read-out at that concentration, not a potency): 89%
Compound 4: middle estimate off by 26 percentage points, on the low side; measured number above the stated range.
By their numbers in this assay, from the lowest: compound 1; then compounds 3, 2 and 4 (each within the scatter of the next).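

In this assay, cyanomethyl in place of cyano does not act alike on the two cores: on the core without the methyl it gives a number 8 percentage points higher from compound 3 to compound 4 (within the scatter), so the change at this position depends on the core: the same change on two cores in this assay, a number 20 percentage points higher (beyond the scatter) from compound 1 to compound 2 and a number 8 percentage points lower (within the scatter) from compound 4 to compound 3, 28 percentage points apart, beyond the scatter of two such steps

Hydrogen in place of methyl, which made no difference beyond the scatter on the shorter chain, gives a number 24 percentage points higher from compound 1 to compound 4 (beyond the scatter) on the longer one, so the effect of the methyl depends on the chain: the same change on two cores in this assay, a number 4 percentage points lower (within the scatter) from compound 2 to compound 3 and a number 24 percentage points higher (beyond the scatter) from compound 1 to compound 4, 28 percentage points apart, beyond the scatter of two such steps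

Among these compounds, the stronger effect appears only where the methyl and the longer chain occur together, in compound 1.

From the compounds shown here alone, whether a still longer nitrile chain, or a carboxylic acid or an amine in place of the nitrile, would keep that effect on the methylated core stays open. A read-out at one concentration gives no potency for any of these compounds.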